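A few compounds are considered here, and "the series" means these few. Any claim that something is new, unique, unknown or untested is made for them only; others in the source may bear on it.

Of the compounds shown here, three of a shared core have been measured in a functional assay on Hs-578T cells (Homo sapiens) for inhibition, read by sulforhodamine B assay, with a stated time of 48 h; a higher number here means a weaker inhibitor of growth, a lower number a stronger inhibitor of growth. Compound 1 `COc1cc(-c2cc(/C=C/C(=O)c3ccc(N)cc3)[nH]n2)cc(OC)c1OC` gives 4330 nM. Compound 2 `COc1ccc(C(=O)/C=C/c2cc(-c3cc(OC)c(OC)c(OC)c3)n[nH]2)cc1OC` gives 2570 nM. Compound 3 `COc1ccc(C(=O)/C=C/c2cc(-c3cc(OC)c(OC)c(OC)c3)n[nH]2)cc1` gives 3600 nM. Among these three numbers compound 3 stands second highest, yet its gap to compound 1 and its gap to compound 2 are both within the scatter, so the three compounds cannot be ranked with confidence.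

Compound 4 `COc1cc(-c2cc(/C=C/C(=O)c3ccc(F)c(F)c3)[nH]n2)cc(OC)c1OC` has not yet been measured. Compared with compound 3 it carries 3,4-difluorophenyl in place of 4-methoxyphenyl on a carbonyl carbon. Every measured step bears on this change, since each one also alters the group attached to the carbonyl carbon or a substituent on that group: a 1.7-fold lower number from compound 1 to compound 2 (0.23 log units; within the scatter), a 1.2-fold lower number from compound 1 to compound 3 (0.08 log units; within the scatter) and a 1.4-fold higher number from compound 2 to compound 3 (0.15 log units; within the scatter). All three steps lie within the scatter. No measured comparison separates one aryl group on the carbonyl carbon from another, and no compound bearing fluorine has been measured, so the incoming group has no direct precedent among these data. The expected step is a 1.1-fold higher number from compound 3 to compound 4 (0.02 log units; within the scatter), which means no change beyond the scatter. Compound 4 is estimated at 3800 nM in this assay, with a range from 1300 nM to 11000 nM.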

Compound 4, concentration for 50% growth inhibition: 3580 nM
Estimate against measurement, compound 4: 1.1-fold (0.03 log units) above, within the range that was stated.
By their numbers in this assay, from the lowest: compounds 2, 4, 3 and 1 (each within the scatter of the next).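

On the carbonyl carbon, 3,4-difluorophenyl brings the first fluorine into the series, and in this assay the swap for 4-methoxyphenyl gives a 1.0-fold lower number from compound 3 to compound 4 (0.00 log units; within the scatter), the swap for 3,4-dimethoxyphenyl gives a 1.4-fold higher number from compound 2 to compound 4 (0.14 log units; within the scatter), and the swap for 4-aminophenyl gives a 1.2-fold lower number from compound 1 to compound 4 (0.08 log units; within the scatter). Rings carrying fluorine, methoxy or an amine at this place therefore cannot be told apart in these four compounds, even though 3,4-difluorophenyl counts no hydrogen-bond acceptor and 4-methoxyphenyl counts one. No measurement of any property of these groups is available to account for this result.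

From the compounds shown here alone, all four compounds keep an aromatic ring on the carbonyl carbon, so it remains open whether a short alkyl chain there, or a phenyl ring bearing a carboxylic acid, would move the number beyond the scatter. Also open, going by these compounds, is what would follow from replacing the methoxy groups that all four compounds share with hydroxy groups, or from lengthening the double-bonded chain.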